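The source may hold more compounds than are shown below. What is called first, only, known or untested is meant among the compounds shown, and "the series" means these compounds.

Measured so far in an ADME assay on isolated protein for inhibition of Amine oxidase [flavin-containing] B (Homo sapiens); on this read-out higher numbers stand for weaker inhibition and lower numbers for stronger inhibition:
compound 1 `C#CCNC1CCc2c(SCc3cccc(F)c3)cccc21` — 11600 nM
compound 2 `C#CCNC1CCc2c(SCc3ccc(C)cc3)cccc21` — 320 nM

Among the measured compounds shown here, compound 1 stands highest of the two numbers; the one step measured is a 36-fold lower number from compound 1 to compound 2 (1.56 log units; beyond the scatter). Compound 3 `C#CCNC1CCc2c(SCc3cccc(C(F)(F)F)c3)cccc21` is not yet measured. It differs from compound 1 by trifluoromethyl in place of fluoro on an aromatic carbon. The measured step changed both the group and its place on the ring, so it bears on this new step only loosely; it does show that the ring substituent can move the number far. For compound 3 a smaller shift in the same direction is expected, a 2.3-fold lower number from compound 1 to compound 3 (0.37 log units; beyond the scatter). Compound 3 is estimated at 5000 nM, with a range of 1500 nM to 16000 nM.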

Compound 3, half-maximal inhibitory concentration: 7710 nM
Estimate against measurement, compound 3: 1.5-fold (0.19 log units) below; the range from low to high includes it.
By their numbers in this assay, from the lowest: compound 2; then compounds 3 and 1 (each within the scatter of the next).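

In this assay, trifluoromethyl in place of fluoro on this aromatic carbon gives a 1.5-fold lower number from compound 1 to compound 3 (0.18 log units; within the scatter), so the larger group does not separate the two compounds. Among the compounds shown here, the earlier step, a 36-fold lower number from compound 1 to compound 2 (1.56 log units; beyond the scatter), thus finds no counterpart in this change at this place. No measurement at hand bears on why the two groups read alike. Still open, on these data alone, is whether the step to compound 2 belongs to the methyl group or to its place on the ring. Also open, as far as these compounds go, is how a methoxy group or a carboxylic acid on this carbon would read.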